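Working notes: from compound 2 to compound 3

The source may report more compounds than this note shows. Statements on the series, on what has been measured and on what is new or still open speak of the compounds shown alone.

Measured so far in a functional assay on MIA PaCa-2 cells (Homo sapiens) for inhibition, read by MTT assay, with a stated time of 72 h (a higher number here means a weaker inhibitor, a lower number a stronger inhibitor), as follows
- compound 1 `COc1cc(NC(C)CCCNC(=O)Nc2cc(C(F)(F)F)cc(C(F)(F)F)c2)c2ncccc2c1` gives 4700 nM as its value
- compound 2 `COc1cc(NC(C)CCCNC(=O)NNC(=O)Nc2cccc(F)c2)c2ncccc2c1` gives 69000 nM as its value

Of the two numbers in this assay the higher belongs to compound 2, and its gap to compound 1 lies beyond the scatter, so compound 2 is the weaker inhibitor of the pair. Compound 3 `COc1cc(NC(C)CCCNC(=O)Nc2cccc(C(F)(F)F)c2)c2ncccc2c1` has not yet been measured. It puts 3-(trifluoromethyl)phenyl in place of ((3-fluorophenyl)carbamoyl)amino on an amide-type nitrogen and so removes the carbamoyl amino stretch of compound 2.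

Among the compounds with values here, no step between measured compounds that differ in one place is available, so the expectation rests on the two values alone. Compound 1, at 4700 nM in this series, also carries a trifluoromethyl-bearing phenyl on an amide-type nitrogen. A fall in the number beyond the scatter is therefore expected in this assay for this change. The estimated size is a 9.9-fold lower number from compound 2 to compound 3 (0.99 log units; beyond the scatter) as a downward step. For compound 3 the expected value is 7000 nM with an estimated range of 3000 nM to 20000 nM in this readout.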

Compound 3, half-maximal inhibitory concentration: 17000 nM
Compound 3: the middle estimate sits 2.4-fold (0.39 log units) below what was measured, and the stated range covers the measured number.
By their numbers in this assay, from the lowest: compound 1; then compound 3; then compound 2.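

In this assay the group on the amide-type nitrogen now has a direct one-place reading: 3-(trifluoromethyl)phenyl in place of ((3-fluorophenyl)carbamoyl)amino gives a 4.1-fold lower number from compound 2 to compound 3 (0.61 log units; beyond the scatter) and so favours the shorter group, although this single change removes the carbamoyl amino stretch and exchanges fluorine for trifluoromethyl together. The aromatic ring on that nitrogen is also shown to matter, as hydrogen in place of trifluoromethyl on an aromatic carbon gives a 3.6-fold higher number from compound 1 to compound 3 (0.56 log units; beyond the scatter) and the second trifluoromethyl therefore goes with the lower number in this pair. The available data give no explanation for either step.

The compounds shown leave open how much of the first step belongs to the lost carbamoyl amino stretch and how much to the exchange of fluorine for trifluoromethyl, which a 3-fluorophenyl group placed directly on the amide-type nitrogen would separate. As far as these compounds go, it also remains open whether trifluoromethyl is specifically required on the aromatic ring or whether a nitrile or a chlorine atom in its place would give a similar number.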